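Working notes: 4-chlorophenyl in place of 3-bromophenyl

The compounds below may be only part of what the source reports. "The series", "measured", "known", "first", "only" and "open" are said of these compounds alone.

Compound 1 (`COc1cc(OC)c(OC)cc1/C=C/COC(=O)/C=C/c1cccc(Br)c1`) gives > 461 umol/kg in a functional assay on the whole organism (strain Kunming) with Mus musculus as the target, with a stated time of 0.5 h (on this read-out higher numbers stand for an effect only at larger amounts of compound and lower numbers for an effect already at smaller amounts), and this value is a limit of the assay and not a number. Compound 1 therefore stands at the limit of > 461 umol/kg in this assay, at which 1 of the 2 values shown sits. Compound 2 (`COc1cc(OC)c(OC)cc1/C=C/COC(=O)/C=C/c1ccc(OC)c(OC)c1OC`) gives 456 umol/kg in this assay. Among the compounds with values here, no measured step connects these two compounds, so the series offers no direct measure of what a single change does.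

The next compound to be read is compound 3 (`COc1cc(OC)c(OC)cc1/C=C/COC(=O)/C=C/c1ccc(Cl)cc1`), which keeps the core of compound 1. The change is 4-chlorophenyl in place of 3-bromophenyl on a double-bonded chain carbon bound to a double-bonded chain carbon.

Within the data shown here, the only numerical anchor is compound 2 at 456 umol/kg, so the expectation stays close to that value and remains loose. The estimated step of an at least 1.0-fold lower number from compound 1 to compound 3 (0.04 log units; that floor lies within the scatter) is expected to stay within the usual scatter, with no firm direction. Another limit reading in this assay would also not be surprising. Compound 3 is expected at 420 umol/kg, with an estimated range of 180 umol/kg to 900 umol/kg.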

Compound 3, dose for half-maximal effect: 364 umol/kg
The estimate for compound 3 lay 1.2-fold (0.06 log units) above the measured number; low and high end bracket the measured number.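

Within the data shown here, replacing 3-bromophenyl with 4-chlorophenyl on a double-bonded chain carbon bound to a double-bonded chain carbon gives the first single-change step in this assay, read as an at least 1.2-fold lower number from compound 1 to compound 3 (0.10 log units; that floor lies within the scatter). The step is only a floor, so it shows neither a real gain nor a real absence of one; what it adds is that this place accepts 4-chlorophenyl while still giving a numerical reading, with the shared core unchanged. The true size of the step stays unknown because compound 1 is read only as a limit: the limit of > 461 umol/kg in this assay, at which 1 of the 3 values shown sits.

Since the halogen and its place on the ring change together, the step cannot separate the two, and 3-chlorophenyl or 4-bromophenyl would be needed to tell whether the exchange of bromine for chlorine or the shift from the 3 to the 4 position carries any difference. Also open, going by these compounds, is how this place responds to a phenyl ring bearing a non-halogen group such as an amine or a carboxylic acid, and whether any such group would move the reading beyond the usual scatter.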